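The source may report more compounds than this note shows. Statements on the series, on what has been measured and on what is new or still open speak of the compounds shown alone.

Measured so far:
Compound 1, `Cc1n[nH]c(C(=O)O)c1Cc1cccc(C(N)=O)c1` — in an assay on isolated protein for inhibition of 2-Hydroxyacid oxidase 2 (Homo sapiens), tested at 10 uM (a lower number here means a weaker effect, a higher number a stronger effect of the compound at the concentration tested), compound 1 gives 8%.
Compound 2, `Cc1n[nH]c(C(=O)O)c1Cc1ccc(C(=O)O)cc1` — in this assay compound 2 gives 22%.

Compound 1 stands lowest of the two numbers. Its nearest neighbour is compound 2, whose number lies higher by a gap that is beyond the usual scatter. Among the compounds with values here, no step between measured compounds that differ in only one place is available, so the pair shows no more than this: both numbers are modest, and compound 2 sits above compound 1.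

The next compound is compound 3, `Cc1n[nH]c(C(=O)O)c1Cc1cccc(OC(F)(F)F)c1`. It differs from compound 1 in one place: trifluoromethoxy in place of carbamoyl on an aromatic carbon. Within the data shown here, nothing measured so far tells how a change of this kind moves the read-out, as compound 2 varies a different part of the molecule than compound 3 does, and the series holds no second pair sharing this exchange.

Expectation: the step of a number 4 percentage points higher from compound 1 to compound 3 (within the scatter) is expected to be small, in either direction, or none beyond the scatter. Compound 3 is estimated at 12%, with a range from 0% to 35%.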

Compound 3, a percentage reported as inhibition, at one concentration (the size of the read-out at that concentration, not a potency): 26%
Beside the measured number, compound 3's estimate is 14 percentage points below it; measured number inside the range.
By their numbers in this assay, from the lowest: compound 1; then compounds 2 and 3 (each within the scatter of the next).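

In this assay, within the data shown here, the place on the aromatic ring that holds carbamoyl in compound 1 proves responsive to exchange: trifluoromethoxy in place of carbamoyl gives a number 18 percentage points higher from compound 1 to compound 3 (beyond the scatter) and provides the first step between compounds that differ in one place. Trifluoromethoxy counts 0 hydrogen-bond donors against 1 for carbamoyl, so a donor in this substituent is not needed for the higher number, although this single step cannot separate that difference from the others between the two groups. No independent measurement bears on the reason for the change.

Open, on these data alone, is whether a methoxy group, a chlorine atom, a nitrile or an amine at this same place would follow trifluoromethoxy or stay close to carbamoyl. Also open, as far as these compounds go, is how the effect of compound 3, at 26%, would change at other concentrations, since this read-out gives only the size of the effect at the one concentration tested.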